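This account rests on a few compounds, and the source may have more. Where it says the series, first, only, none or still open, it means among the compounds named here.

In an ADME assay on HEp-2 cells (Homo sapiens) for cytotoxicity, read by MTT assay, with a stated time of 72 h (on this read-out lower numbers stand for stronger inhibition and higher numbers for weaker inhibition), compound 2 `COc1cc(C2=C(c3cc(C)c(OC)c(C)c3)C(OC(C)=O)CC2=O)cc(OC)c1OC` gives > 100 ug/mL, which is a limit of the assay and not a number. Compound 1 `COc1cc(C2=C(c3cc(C)c(OC)c(C)c3)C(O)CC2=O)cc(OC)c1OC` also gives only a limit, > 100 ug/mL. Compound 2 therefore has no exact place on the scale: it shares the limit of > 100 ug/mL in this assay, at which 2 of the 3 values shown sit, with compound 1. Among the compounds with values here, compound 3 `COc1ccc(C2=C(c3cc(OC)c(OC)c(OC)c3)C(=O)C(O[SiH2]C(C)(C)C)C2)cc1` is the only one with a true number, 16 ug/mL.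

The next structure is compound 4 `COc1ccc(C2=C(c3cc(OC)c(OC)c(OC)c3)C(=O)CC2OC(C)=O)cc1NC=O`. It carries 3-(formylamino)-4-methoxyphenyl in place of 4-methoxy-3,5-dimethylphenyl on a double-bonded ring carbon, a change counted as 3-(formylamino)-4-methoxyphenyl in place of 4-methoxy-3,5-dimethylphenyl on a double-bonded ring carbon.

Within the data shown here, the only measured step, a step that the two limits leave unreadable from compound 1 to compound 2, involves a different change and has no readable size, so it offers no size to carry over. Among the measured compounds shown here, no measured pair shows this exchange of groups either. The expectation therefore rests on little. Compound 2 at > 100 ug/mL leaves room for a readable step only toward stronger inhibition, and compound 3 at 16 ug/mL shows that a number can be reached among these compounds. The expected change in this assay is a modest one toward stronger inhibition, estimated as an at least 2.0-fold lower number from compound 2 to compound 4 (0.30 log units; that floor lies within the scatter), and another limit would be no surprise. For compound 4 the estimate is 50 ug/mL, with an expected range of 12 ug/mL to 150 ug/mL.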

Compound 4, half-maximal inhibitory concentration: 3.27 ug/mL
Beside the measured number, compound 4's estimate is 15-fold (1.18 log units) above it; the measured number lies below the stated range.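

In this assay, within the data shown here, putting 3-(formylamino)-4-methoxyphenyl in place of 4-methoxy-3,5-dimethylphenyl on a double-bonded ring carbon gives the first readable step in this set: an at least 30-fold lower number from compound 2 to compound 4 (1.48 log units; beyond the scatter). This shows that the aryl group at this position can carry these compounds from no measurable effect to a true number, something the earlier pair could not show, since the step between its two limits cannot be read. The size printed for the step is only a floor, and the real gap may be larger, because compound 2 has a limit and not a number: the limit of > 100 ug/mL in this assay, at which 2 of the 4 values shown sit.

The compounds shown leave open which part of the exchange matters, whether the formylamino group that enters or the methyl groups that leave, since both change in the same step. They also leave open how the read-out would respond if a free amine or an acetylamino group stood in place of the formylamino group on the same methoxyphenyl ring.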